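Swapping a butyl chain for a fluorinated benzyl group

This account rests on a few compounds, and the source may have more. Where it says the series, first, only, none or still open, it means among the compounds named here.

Measured so far:
compound 1 `O=C(O)c1ccccc1-c1ccc(CCc2ncc(C3CCCCC3)[nH]2)cc1` gives 14.7 nM in an in vitro functional assay on cells for agonist activity at Bombesin receptor subtype-3 (Mus musculus), read by luminescence and calcium flux; a lower number here means that less compound is needed, a higher number that more compound is needed for the effect
compound 2 `CCCCc1cnc(CCc2ccc(-c3ccccc3C(=O)O)cc2)[nH]1` gives 93 nM in this assay

Among the compounds with values here, compound 2 stands at the higher of the two numbers in this assay; its nearest neighbour is compound 1, and the only step across these two, a 6.3-fold higher number from compound 1 to compound 2 (0.80 log units; beyond the scatter), lies beyond the scatter. The next compound, compound 3 `O=C(O)c1ccccc1-c1ccc(CCc2ncc(Cc3ccc(F)cc3)[nH]2)cc1`, is not yet measured in this assay. It differs from compound 2 in one place: 4-fluorophenyl in place of propyl on a saturated chain carbon bound to an aromatic carbon. Within the data shown here, only the step from compound 1 to compound 2 bears on this change, and it went in the direction of a higher number when a ring was replaced by an open chain. Compound 3 reverses that direction in spirit, putting a ring back into the same part of the molecule, though a flat aromatic one with a fluorine rather than the saturated ring of compound 1. A lower number than compound 2 is therefore expected in this assay, by a step of about a 2.3-fold lower number from compound 2 to compound 3 (0.37 log units; beyond the scatter), and the value of compound 3 is estimated at 40 nM, within a range from 8 nM to 200 nM.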

Compound 3, half-maximal effective concentration: 50 nM
For compound 3 the middle estimate is 1.3-fold (0.10 log units) below the measured one, within the range that was stated.
By their numbers in this assay, from the lowest: compound 1; then compounds 3 and 2 (each within the scatter of the next).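

In this assay, putting 4-fluorophenyl in place of propyl on a saturated chain carbon bound to an aromatic carbon gives a 1.9-fold lower number from compound 2 to compound 3 (0.27 log units; within the scatter) and so does not separate the two groups: the open butyl chain and the ring-bearing 4-fluorobenzyl group cannot be told apart at this position. A ring in this part of the molecule is therefore not enough on its own to reach the low number of compound 1, as exchanging the cyclohexyl group for the 4-fluorobenzyl group gives a 3.4-fold higher number from compound 1 to compound 3 (0.53 log units; beyond the scatter) and this step is larger than the scatter, so the kind of group matters here and not merely the presence of a ring. Nothing among the available data explains why cyclohexyl stands apart from the other two groups.

The compounds shown leave open what the fluorine contributes, a question that a plain benzyl group would address. They also leave open whether the low number of compound 1 depends on the saturated ring itself or on that ring sitting directly on the aromatic carbon, which cyclohexylmethyl or a directly attached phenyl ring could help to separate.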